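Swapping the fluorobenzyl ether of compound 1 for hexyl

This account rests on a few compounds, and the source may have more. Where it says the series, first, only, none or still open, it means among the compounds named here.

Measured compounds:
compound 1, `CN(C)CCNc1ccnc2cc(OCc3ccc(F)cc3)ccc12`, 790 nM
compound 2, `CN(C)CCCNc1ccnc2cc(OCc3ccc(F)cc3)ccc12`, 1570 nM

In a functional assay on HepG2 cells (Homo sapiens) for cytotoxicity, read by MTT assay, with a stated time of 48 h (on this read-out lower numbers stand for stronger inhibition and higher numbers for weaker inhibition), compound 1 gives 790 nM, the lowest of the two numbers shown. Its nearest neighbour is compound 2, which gives 1570 nM; the step of a 2.0-fold higher number from compound 1 to compound 2 (0.30 log units; within the scatter) is within the scatter, so the two compounds cannot be separated on this read-out.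

Compound 3, `CCCCCCOc1ccc2c(NCCN(C)C)ccnc2c1`, has not yet been measured in this assay. It differs from compound 1 in one place: pentyl in place of 4-fluorophenyl on a saturated chain carbon bound to an oxygen on an aromatic ring. Among the compounds with values here, the only measured step, from compound 1 to compound 2, concerns the chain on the ring nitrogen and leaves the ether side untouched, so nothing measured here bears on the change to compound 3. Within the data shown here, with no measured step to lean on, compound 3 is expected to land near compound 1, and any step expected in this assay is small relative to the scatter. Among the measured compounds shown here, the expected step of a 1.5-fold higher number from compound 1 to compound 3 (0.18 log units; within the scatter) reflects only this lack of information, and the range is accordingly wide. Compound 3 is estimated at 1200 nM, between 350 nM and 4500 nM.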

Compound 3, half-maximal inhibitory concentration: 1370 nM
For compound 3 the middle estimate is 1.1-fold (0.06 log units) below the measured one; low and high end bracket the measured number.
By their numbers in this assay, from the lowest: compounds 1, 3 and 2 (each within the scatter of the next).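

In this assay the ether side of the shared core now has a measured step of its own, and going from 4-fluorobenzyl to hexyl gives a 1.7-fold higher number from compound 1 to compound 3 (0.24 log units; within the scatter), so the two ethers cannot be told apart on this read-out. At this place, on a saturated chain carbon bound to an oxygen on an aromatic ring, the six-membered aromatic ring of 4-fluorophenyl and its fluorine give way to a pentyl with no ring, and the number stays within the scatter, so for this pair a ring at this place is not needed for a value in this range. Nothing measured on these compounds offers a reason for this result.

From the compounds shown here alone, it remains open whether the same holds for a benzyl ether without the fluorine, for a chain shorter or longer than hexyl, or for an ether chain ending in an amine or a carboxylic acid. Going by these compounds, it is also open whether the hexyl ether would read the same when joined to the amine side chain of compound 2.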